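The source may hold more compounds than are shown below. What is called first, only, known or untested is meant among the compounds shown, and "the series" means these compounds.

Measured so far in a functional assay on RT-112 cells (Homo sapiens) for antiproliferative activity, read by MTT assay, with a stated time of 72 h; on this read-out higher numbers stand for weaker inhibition of growth and lower numbers for stronger inhibition of growth:
compound 1 `COc1cc(NC(=O)Nc2cccc3c(Nc4cc(OC)cc(OC)c4)ncnc23)cc(OC)c1`: 366 nM
compound 2 `COc1cc(Nc2ncnc3c(NC(=O)Nc4cc(Cl)cc(Cl)c4)cccc23)cc(OC)c1`: 30.2 nM
compound 3 `COc1cc(Nc2ncnc3c(NC(=O)Nc4cc(F)cc(F)c4)cccc23)cc(OC)c1`: 2630 nM

Among these three, compound 1 holds the second-highest number, and both of its neighbours lie beyond the scatter: a 12-fold lower number from compound 1 to compound 2 (1.08 log units; beyond the scatter), whereas a 7.2-fold higher number from compound 1 to compound 3 (0.86 log units; beyond the scatter). Between the two halogenated analogues, an 87-fold higher number from compound 2 to compound 3 (1.94 log units; beyond the scatter). The group on the amide-type nitrogen is thus the only point varied so far, and exchanging it moves the read-out strongly in either direction.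

Compound 4 `COc1cc(Nc2ncnc3c(NC(=O)Nc4cc(C)cc(C)c4)cccc23)cc(OC)c1` has not yet been measured. Its change from compound 1 is 3,5-dimethylphenyl in place of 3,5-dimethoxyphenyl on an amide-type nitrogen. The two steps that bear on it, from compound 1 to compound 2 and from compound 1 to compound 3, were both large, one downward and one upward, so a step beyond the scatter is likely, but neither step settles its direction for a 3,5-dimethylphenyl group. Compound 4 is expected to land between the two measured extremes, at about 120 nM in this assay, with a wide range from 25 nM to 600 nM. The expected step is a 3.1-fold lower number from compound 1 to compound 4 (0.48 log units; beyond the scatter).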

Compound 4, concentration for 50% growth inhibition: 10100 nM
The estimate for compound 4 lay 84-fold (1.93 log units) below the measured number; measured number outside the range, above it.
By their numbers in this assay, from the lowest: compound 2; then compound 1; then compound 3; then compound 4.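

In this assay, 3,5-dimethylphenyl on the amide-type nitrogen gives a 28-fold higher number from compound 1 to compound 4 (1.44 log units; beyond the scatter) and a 3.8-fold higher number from compound 3 to compound 4 (0.58 log units; beyond the scatter) and also a 330-fold higher number from compound 2 to compound 4 (2.52 log units; beyond the scatter) as the steps to this group, so it sits at the high end of the four numbers. The order from the lowest number runs 3,5-dichlorophenyl, 3,5-dimethoxyphenyl, 3,5-difluorophenyl, 3,5-dimethylphenyl, which separates the two halogenated groups and shows that a carbon-only replacement for the 3,5-dimethoxyphenyl group does not keep the read-out near that of compound 1. Nothing available accounts for this order.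

Open, on these data alone, is whether 3,5-dibromophenyl or 3,5-bis(trifluoromethyl)phenyl would extend the low number of compound 2. Also open, as far as these compounds go, is how an unsubstituted phenyl or a phenyl carrying a single chlorine would compare at this nitrogen.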